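The source may hold more compounds than are shown below. What is called first, only, known or untested is meant among the compounds shown, and "the series" means these compounds.

In a physicochemical assay for solubility (a lower number here means a less soluble compound, a higher number a more soluble compound), the series offers little to go on. Compound 1 (`CS(=O)(=O)c1ccc(-n2nc(C(F)F)c(C#N)c2-c2ccccc2)cc1`) reads "not determined" (no result reported), and compound 2 (`CS(=O)(=O)c1ccc(-n2nc(C(F)F)c(C#N)c2-c2cc(F)cc(F)c2)cc1`) reads "not determined" (no result reported). Within the data shown here, compound 3 (`CS(=O)(=O)c1ccc(-n2nc(C(F)F)c(C#N)c2NC2CCCC2)cc1`) gives 100 ug/mL, the only number available, so it cannot be ranked against any other compound. Compound 4 (`CC(C)(C)CNc1c(C#N)c(C(F)F)nn1-c1ccc(S(C)(=O)=O)cc1`) has yet to be measured. It carries neopentyl in place of cyclopentyl on a nitrogen on an aromatic ring. Among the measured compounds shown here, no measured step between related compounds is available as a guide, so the expectation rests on this change alone. The expected step, a 1.3-fold lower number from compound 3 to compound 4 (0.10 log units; within the scatter), stays within the usual scatter. In this assay, the estimate for compound 4 is 80 ug/mL, with an expected range of 30 ug/mL to 140 ug/mL.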

Compound 4, solubility: > 200 ug/mL
Compound 4: only a limit was reported (the forecaster's own chance of this, stated with the estimate: 15%); middle value at least 2.5-fold (0.39 log units) away from the limit.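

In this assay compound 4 gives > 200 ug/mL, which is a limit of the assay and not a number. Neopentyl in place of cyclopentyl on a nitrogen on an aromatic ring gives the first step at this position, an at least 2.0-fold higher number from compound 3 to compound 4 (0.30 log units; that floor lies within the scatter), so opening the ring brings no loss in the read-out here. The size of that step remains unfixed: the limit of > 200 ug/mL in this assay, at which 1 of the 4 values shown sits.

On these data alone, how far compound 4 lies past its limit remains open. So does how a longer chain or a carboxylic acid would read on the same nitrogen.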